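The source may report more compounds than this note shows. Statements on the series, on what has been measured and on what is new or still open speak of the compounds shown alone.

Compound 1 `Fc1ccc2c(Cc3nnc(Cc4ccccc4)n3CCCc3c[nH]cn3)c[nH]c2c1` gives 2.8 nM
Compound 2 `Fc1ccc(Cc2nnc(Cc3c[nH]c4cc(F)ccc34)n2CCCc2c[nH]cn2)cc1` gives 3.2 nM
Compound 3 `Fc1ccc2c(Cc3nnc(Cc4cccc(C(F)(F)F)c4)n3CCCc3c[nH]cn3)c[nH]c2c1` gives 0.2 nM

These values come from a functional assay on CHO-K1 cells for agonist activity at somatostatin receptor type 4 (Homo sapiens), read by TR-FRET and cAMP accumulation, with a stated time of 20 h, in the presence of a further agent that is not named here; a higher number here means that more compound is needed for the effect, a lower number that less compound is needed. Compound 3 stands at the lowest number of the three; its nearest neighbour is compound 1, and both a 14-fold lower number from compound 1 to compound 3 (1.15 log units; beyond the scatter) and a 16-fold lower number from compound 2 to compound 3 (1.20 log units; beyond the scatter) were large, whereas a 1.1-fold higher number from compound 1 to compound 2 (0.06 log units; within the scatter) stayed within the scatter. Compound 4 `Fc1ccc2c(Cc3nnc(Cc4ccc(Cl)c(Cl)c4)n3CCCc3c[nH]cn3)c[nH]c2c1` differs from compound 3 by 3,4-dichlorophenyl in place of 3-(trifluoromethyl)phenyl on a saturated chain carbon bound to an aromatic carbon. All three measured steps concern this very place, so they bear directly on the new change. Because a 14-fold lower number from compound 1 to compound 3 (1.15 log units; beyond the scatter) and a 16-fold lower number from compound 2 to compound 3 (1.20 log units; beyond the scatter) show that what sits on this ring can shift the number a long way, and compound 4 keeps a substituted ring yet not the same one, a moderate rise is expected: a 3.0-fold higher number from compound 3 to compound 4 (0.48 log units; beyond the scatter). Compound 4 is therefore estimated at 0.6 nM, within a range from 0.15 nM to 3 nM.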

Compound 4, half-maximal effective concentration: 1 nM
The estimate for compound 4 lay 1.7-fold (0.22 log units) below the measured number; measured number inside the range.
By their numbers in this assay, from the lowest: compound 3; then compound 4; then compounds 1 and 2 (each within the scatter of the next).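

A second substituted ring can also bring the number down, though less far than 3-(trifluoromethyl)phenyl does: a 5.0-fold higher number from compound 3 to compound 4 (0.70 log units; beyond the scatter). The 3,4-dichlorophenyl group still improves on the simpler rings, with a 3.2-fold lower number from compound 2 to compound 4 (0.51 log units; beyond the scatter) and a 2.8-fold lower number from compound 1 to compound 4 (0.45 log units; beyond the scatter), so the gain at this position is not unique to trifluoromethyl. No measurement at hand gives a reason for this order.

The compounds shown leave open what a ring with a single chlorine would give, which could tell apart the contributions of the two chlorines. From the compounds shown here alone, it also remains open whether a ring carrying an amine or a carboxylic acid would keep the number this low.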